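The compounds below may be only part of what the source reports. "The series", "measured", "known", "first", "only" and "open" are said of these compounds alone.

Compound 1, `N=C(S)CCCn1nc(-c2ccccc2)ccc1=O`, gives 31.9 mg/kg in a functional assay on the whole organism (stomach) with Rattus norvegicus as the target; on this read-out higher numbers stand for an effect only at larger amounts of compound and lower numbers for an effect already at smaller amounts.
Compound 2, `Cc1ccc(=O)n(CCCCCCC(=N)S)n1`, in this assay is reported only as a limit, > 100 mg/kg.
Compound 3, `N=C(S)CCCCCn1nc(-c2ccccc2)ccc1=O`, gives 23.3 mg/kg in this assay.

Compound 1 and compound 3 share one core and differ in a single place: a group of 3 heavy atoms (1 carbon, 1 nitrogen, 1 sulfur; no ring) in place of a group of 5 heavy atoms (3 carbon, 1 nitrogen, 1 sulfur; no ring), on a saturated chain carbon, three bonds along the chain from an aromatic nitrogen. The step is a 1.4-fold higher number from compound 3 to compound 1 (0.14 log units; within the scatter), so the two values show no difference that can be trusted. Compound 2 is built on another core; the difference between the two cores is not broken down here, and compound 2 reaches only the limit of this assay, (the limit of > 100 mg/kg in this assay, at which 1 of the 3 values shown sits).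

Compound 4, `Cc1ccc(=O)n(CCCCC(=N)S)n1`, has not yet been measured. It is related to compound 2 by a group of 3 heavy atoms (1 carbon, 1 nitrogen, 1 sulfur; no ring) in place of a group of 5 heavy atoms (3 carbon, 1 nitrogen, 1 sulfur; no ring), on a saturated chain carbon, four bonds along the chain from an aromatic nitrogen. For the measured compounds named here, this is the same kind of change as that from compound 3 to compound 1, though not the same: in the one pair the change sits three bonds along the chain from an aromatic nitrogen, in the other four bonds along the chain from an aromatic nitrogen. Since the measured step of this kind lay within the scatter, the step from compound 2 to compound 4 is expected to be small as well, about a step that the limit leaves unreadable from compound 2 to compound 4, resting on a 1.4-fold higher number from compound 3 to compound 1 (0.14 log units; within the scatter). Compound 4 is therefore estimated to fall near 150 mg/kg, within 50 mg/kg to 450 mg/kg, and it is expected that the assay may again report only a limit for compound 4, as it did for compound 2 with > 100 mg/kg.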

Compound 4, dose for half-maximal effect: > 100 mg/kg
Compound 4: a limit, no number; the forecaster's own chance of this, stated with the estimate: 65%; the middle value does not contradict the limit.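

In this assay compound 4, like compound 2, is reported only as a limit, so no step can be read between these two compounds: the limit of > 100 mg/kg in this assay, at which 2 of the 4 values shown sit.

The compounds shown leave open where compound 2 and compound 4 lie as actual numbers, and whether a group of 3 heavy atoms in place of a group of 5 heavy atoms changes anything on the core of compound 2.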